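The source may hold more compounds than are shown below. What is called first, only, known or untested is meant among the compounds shown, and "the series" means these compounds.

Measured compounds:
- compound 1, `C1=C(/C=C/c2ccncc2)COc2ccccc21`, 75000 nM
- compound 2, `Clc1ccc2c(c1)C=C(/C=C/c1ccncc1)CO2`, 75000 nM
- compound 3, `O=c1c(/C=C/c2ccncc2)coc2ccccc12`, > 100000 nM

In an ADME assay on HeLa cells (Homo sapiens) for cytotoxicity, read by XTT assay, with a stated time of 3 days (on this read-out higher numbers stand for lower toxicity in this test and lower numbers for higher toxicity in this test), compound 1 gives 75000 nM. Compound 2 carries the change chloro in place of hydrogen on an aromatic carbon on the core of compound 1, and in this assay compound 2 gives 75000 nM. The step of no change at the digits printed from compound 1 to compound 2 (within the scatter) is therefore flat. Compound 3 has a different core; the difference between the core of compound 3 and the core of compound 1 is not broken down here. For compound 3 the value in this assay is a limit of the assay and not a number: > 100000 nM. This sits at the limit of > 100000 nM in this assay, at which 1 of the 3 values shown sits.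

Compound 4, `O=c1c(/C=C/c2ccncc2)coc2ccc(Cl)cc12`, is not yet measured. It stands to compound 3 as compound 2 stands to compound 1: the change is chloro in place of hydrogen on an aromatic carbon, and its place reads the same as the place of the change from compound 1 to compound 2, so it is the same change on a different core. For compound 4 in this assay the step that the limit leaves unreadable from compound 3 to compound 4 is expected to be about as flat, because no change at the digits printed from compound 1 to compound 2 (within the scatter) shows no change for the same change there. Since compound 3 itself is known only as a limit, compound 4 is expected to come out again at or beyond that limit, with an estimated value of 130000 nM, between 60000 nM and 300000 nM.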

Compound 4, half-maximal cytotoxic concentration: 150000 nM
For compound 4 the middle estimate is 1.2-fold (0.06 log units) below the measured one; the range from low to high includes it.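

In this assay no step can be read between compound 3 and compound 4, because the result for compound 3 is a limit of the assay and not a number: the limit of > 100000 nM in this assay, at which 1 of the 4 values shown sits.

The compounds shown leave open whether chloro in place of hydrogen on an aromatic carbon is as flat on the core of compound 3 as on the core of compound 1.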